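A few compounds are considered here, and "the series" means these few. Any claim that something is new, unique, unknown or untested is made for them only; others in the source may bear on it.

Measured compounds:
compound 1 `CCOc1ncc(-c2nc(C(F)(F)F)sc2N2CCN(C(=O)Cn3cnc4cccnc43)[C@H](C)C2)cn1` gives 48 nM
compound 2 `CCOc1ncc(-c2nc(C(F)(F)F)sc2N2CCN(C(=O)Cn3ccc4cccnc43)[C@H](C)C2)cn1` gives 47 nM
compound 3 `CCOc1ncc(-c2nc(C(F)(F)F)sc2N2CCN(C(=O)Cn3ccc4cnccc43)[C@H](C)C2)cn1` gives 25 nM

All three were tested in an assay on blood for inhibition of C-X-C chemokine receptor type 3 (Homo sapiens), with a stated time of 30 min; on this read-out lower numbers stand for stronger inhibition and higher numbers for weaker inhibition. The three compounds share one core and differ only in the bicyclic aromatic group attached on a saturated chain carbon bound to a carbonyl carbon. Compound 3 shows the lowest of the three numbers, but the step of a 1.9-fold lower number from compound 2 to compound 3 (0.27 log units; within the scatter) and the step of a 1.9-fold lower number from compound 1 to compound 3 (0.28 log units; within the scatter) both lie within the scatter, so no real difference among the three is established. The swap a 1.0-fold lower number from compound 1 to compound 2 (0.01 log units; within the scatter) is likewise within the scatter.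

Compound 4 `CCOc1ncc(-c2nc(C(F)(F)F)sc2N2CCN(C(=O)Cn3ncc4cccnc43)[C@H](C)C2)cn1` carries another bicyclic group at the same place: a group of 9 heavy atoms (6 carbon, 3 nitrogen; one five-membered aromatic ring with 2 hetero atoms, one six-membered aromatic ring with 1 hetero atom) in place of a group of 9 heavy atoms (7 carbon, 2 nitrogen; one five-membered aromatic ring with 1 hetero atom, one six-membered aromatic ring with 1 hetero atom), on a saturated chain carbon bound to a carbonyl carbon. Every measured swap of this bicyclic group has stayed within the scatter, so the same is expected here: a step of a 1.5-fold higher number from compound 3 to compound 4 (0.18 log units; within the scatter) in this assay is estimated, with no direction asserted beyond the scatter. Compound 4 is therefore expected to give about 38 nM in this assay, within a range from 17 nM to 90 nM.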

Compound 4, half-maximal inhibitory concentration: 372 nM
The estimate for compound 4 lay 9.8-fold (0.99 log units) below the measured number; measured number outside the range, above it.
By their numbers in this assay, from the lowest: compounds 3, 2 and 1 (each within the scatter of the next); then compound 4.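

In this assay, the place on a saturated chain carbon bound to a carbonyl carbon turns out not to accept every bicyclic group equally, as the data show a 15-fold higher number from compound 3 to compound 4 (1.17 log units; beyond the scatter) and a 7.9-fold higher number from compound 2 to compound 4 (0.90 log units; beyond the scatter), both beyond the scatter. The most telling comparison is a 7.8-fold higher number from compound 1 to compound 4 (0.89 log units; beyond the scatter), also beyond the scatter, as the two groups in this pair have the same counts of carbon and nitrogen atoms and the same ring description, so these counts alone do not decide the result and the arrangement of atoms inside the group must differ in a way that matters. No measurement is available that bears on why the group in compound 4 gives the higher number.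

As far as these compounds go, it remains open whether other groups at this place, such as a plain phenyl ring or a bicyclic group carrying an amine or a carboxylic acid, would stay close to compound 1, compound 2 and compound 3 or move as far as compound 4. From the compounds shown here alone, it is also open whether the same swap would give a step of similar size with a longer chain in place of the saturated chain carbon.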